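The source may report more compounds than this note shows. Statements on the series, on what has been measured and on what is new or still open speak of the compounds shown alone.

Compound 1 `CC(C(=O)NCc1ccc(C(F)(F)F)nc1Nc1ccccc1)c1ccc(NS(C)(=O)=O)c(F)c1`: 1400 nM
Compound 2 `CC(C(=O)NCc1ccc(C(F)(F)F)nc1N(C)c1ccccc1)c1ccc(NS(C)(=O)=O)c(F)c1`: 57.4 nM
Compound 3 `CC(C(=O)NCc1ccc(C(F)(F)F)nc1N1CCC(C(=O)c2ccc(F)cc2)CC1)c1ccc(NS(C)(=O)=O)c(F)c1`: 990 nM

In a functional assay on CHO-K1 cells for antagonist activity at transient receptor potential cation channel subfamily V member 1 (Homo sapiens), read by FLIPR (on this read-out lower numbers stand for stronger inhibition and higher numbers for weaker inhibition), compound 1 gives 1400 nM, the highest of the three numbers. Compound 3 is nearest, with 990 nM, and the gap between the two lies within the usual scatter. Compound 2 is furthest away, with 57.4 nM.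

Compound 4 `CC(C(=O)NCc1ccc(C(F)(F)F)nc1N1CCC(CN(C)C)CC1)c1ccc(NS(C)(=O)=O)c(F)c1` differs from compound 1 in a single respect: 4-((dimethylamino)methyl)piperidin-1-yl in place of anilino on an aromatic carbon.

Going by the values given here, one measured step bears on this change. It is a 24-fold lower number from compound 1 to compound 2 (1.39 log units; beyond the scatter), where a methyl replaced the hydrogen on a nitrogen on an aromatic ring and the number fell by a large margin. Compound 4 likewise has no hydrogen left on that nitrogen, but the group it brings in is a saturated ring rather than a methyl. Compound 3 is the closer precedent here: it also carries a piperidin-1-yl group bearing a substituent in place of the anilino group, and its value sits within the scatter of that of compound 1. Among the compounds with values here, no computed step joins compound 1 and compound 3, so only their two numbers speak.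

Weighing these, the step of a 1.4-fold lower number from compound 1 to compound 4 (0.15 log units; within the scatter) is expected to be small, and compound 4 is estimated at 1000 nM, within a range from 300 nM to 3500 nM.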

Compound 4, half-maximal inhibitory concentration: 426 nM
Beside the measured number, compound 4's estimate is 2.3-fold (0.37 log units) above it; measured number inside the range.
By their numbers in this assay, from the lowest: compound 2; then compound 4; then compounds 3 and 1 (each within the scatter of the next).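

In this assay, the step of a 3.3-fold lower number from compound 1 to compound 4 (0.52 log units; beyond the scatter) shows that a saturated ring on this aromatic carbon, next to the ring nitrogen, can give a number lower than that of the anilino compound by more than the scatter, whereas compound 3, with its own substituted piperidin-1-yl group, stayed within the scatter of compound 1. The step of a 2.3-fold lower number from compound 3 to compound 4 (0.37 log units; beyond the scatter) adds that the substituent on the saturated ring carbon counts, not the piperidin-1-yl ring alone, since (dimethylamino)methyl and (4-fluorophenyl)carbonyl give numbers that differ beyond the scatter. Even so, the step of a 7.4-fold higher number from compound 2 to compound 4 (0.87 log units; beyond the scatter) leaves methyl(phenyl)amino the better of the two groups at this position in this assay, and nothing measured here explains any of these differences.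

The compounds shown leave open how a piperidin-1-yl ring with no substituent would read, and whether a primary aminomethyl or a hydroxymethyl group would hold the number of compound 4. They also leave open whether an ethyl in place of the methyl of methyl(phenyl)amino would keep the low number of compound 2.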